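Adding a Butyl Chain to the Shared Core

A few compounds are considered here, and "the series" means these few. Any claim that something is new, unique, unknown or untested is made for them only; others in the source may bear on it.

Measured compounds:
compound 1 `COc1ccc(-c2cccc(C(=O)Nc3nn[nH]n3)n2)cc1` with 12%
compound 2 `CCc1ccc(-c2cccc(C(=O)Nc3nn[nH]n3)n2)cc1` with 39%

In a functional assay on the whole organism for inhibition, with Rattus norvegicus as the target, at a dose of 1 mg/kg by the oral route (on this read-out higher numbers stand for a stronger effect at the one dose given and lower numbers for a weaker effect), compound 1 gives 12% and compound 2 gives 39%. Compound 2 stands highest of the two numbers, separated from its nearest neighbour by a number 27 percentage points higher from compound 1 to compound 2 (beyond the scatter), the change being ethyl in place of methoxy on an aromatic carbon. Compound 3 `CCCCc1cc(C(=O)Nc2nn[nH]n2)nc(-c2ccc(CC)cc2)c1` keeps the ethyl group and differs from compound 2 by butyl in place of hydrogen on an aromatic carbon. Within the data shown here, no measured step bears directly on this change: the single measured step concerns a different exchange at a different place, so it offers only weak guidance for compound 3. Compound 3 is therefore expected, with considerable uncertainty, to give about 45% in this assay, within a range from 20% to 70%. The estimated step of a number 6 percentage points higher from compound 2 to compound 3 (within the scatter) is expected to lie close to the scatter rather than beyond it.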

Compound 3, a percentage reported as inhibition, in the whole organism at one dose (the size of the read-out at that dose, not a potency): 19%
Compound 3: the middle estimate sits 26 percentage points above what was measured; measured number outside the range, below it.
By their numbers in this assay, from the lowest: compounds 1 and 3 (each within the scatter of the next); then compound 2.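

Butyl in place of hydrogen, on the carbon opposite the ring nitrogen, gives a number 20 percentage points lower from compound 2 to compound 3 (beyond the scatter) in this assay. Among these compounds, this is the first reading at this carbon, and it shows that the position is not indifferent to substitution: with the ethyl group kept, the compound carrying hydrogen there gives the higher number at the one oral dose. No measurement presented here accounts for this drop.

The compounds shown leave open whether the lower number belongs to butyl in particular or to any group at this carbon, since a methyl group, a shorter chain ending in a hydroxyl or an amine would each test that. They also leave open whether butyl gives a step of similar size when methoxy stands in place of ethyl.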